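This account rests on a few compounds, and the source may have more. Where it says the series, first, only, none or still open, it means among the compounds named here.

Measured compounds in this series:
compound 1, `COc1ccc(CNC(=O)/C(C#N)=C/c2ccc[nH]2)cc1`, in a functional assay on A2780 cells (Homo sapiens) for inhibition, read by MTT assay, with a stated time of 72 h (on this read-out lower numbers stand for stronger inhibition of growth and higher numbers for weaker inhibition of growth), gives > 50000 nM, a limit of the assay;
compound 2, `COc1ccc(CNC(=O)/C(C#N)=C/c2ccco2)cc1`, in this assay gives 24000 nM;
compound 3, `N#C/C(=C\c1ccco1)C(=O)NCc1ccc(Cl)c(Cl)c1`, in this assay gives > 50000 nM, a limit of the assay.

Compound 2 thus holds the only number shown; the other two values sit at a limit (the limit of > 50000 nM in this assay, at which 2 of the 3 values shown sit). Compound 4, `COc1ccc(CNC(=O)/C(C#N)=C/c2ccc(C)o2)cc1`, is not yet measured. It differs from compound 2 by methyl in place of hydrogen on an aromatic carbon, a methyl in place of hydrogen on an aromatic carbon of the furan-2-yl, giving 5-methylfuran-2-yl. For the measured compounds named here, the single measured step, an at least 2.0-fold lower number from compound 1 to compound 2 (0.31 log units; beyond the scatter), concerns exchange of the ring itself, not a methyl on it, so no measured step bears directly on this change. For compound 4 a step within the scatter is expected, a 1.2-fold lower number from compound 2 to compound 4 (0.08 log units; within the scatter). Compound 4 is estimated at 20000 nM, within 8000 nM to 55000 nM.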

Compound 4, concentration for 50% growth inhibition: 60000 nM
Estimate against measurement, compound 4: 3.0-fold (0.48 log units) below; the whole stated range lies below it.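

In this assay, the furan-2-yl of compound 2 does not accept a methyl on the aromatic carbon next to the ring oxygen without loss, with a 2.5-fold higher number from compound 2 to compound 4 (0.40 log units; beyond the scatter). For the compounds shown here, this is the first read on substitution of the ring rather than exchange of it, and 5-methylfuran-2-yl goes the wrong way for growth inhibition. The step between compound 1 and compound 4 cannot be read because compound 1 stands at a limit: the limit of > 50000 nM in this assay, at which 2 of the 4 values shown sit.

From the compounds shown here alone, whether an ethyl or a carboxylic acid at this carbon would behave like methyl remains open. So does whether the methyl step carries over to the 1H-pyrrol-2-yl ring.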